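This account rests on a few compounds, and the source may have more. Where it says the series, first, only, none or still open, it means among the compounds named here.

Values in an ADME assay (liver) for metabolic stability, with Liver microsome (Homo sapiens) as the target, using microsomes and NADPH, with a stated time of 30 min, tested at 1 uM; a higher number here means faster removal of the compound, a lower number slower removal:
- Compound 1 `Nc1ccc(S(=O)(=O)N2CCN(c3ncc(C(O)(C(F)(F)F)C(F)(F)F)cc3C#CC3CC3)CC2)cn1`: < 14 mL.min-1.g-1, a limit of the assay and not a number
- Compound 2 `CS(=O)(=O)Nc1cccc(-c2cc(C(O)(C(F)(F)F)C(F)(F)F)cnc2N2CCN(S(=O)(=O)c3ccc(N)nc3)CC2)c1`: 40 mL.min-1.g-1
- Compound 3 `COc1cncc(-c2cc(C(O)(C(F)(F)F)C(F)(F)F)cnc2N2CCN(S(=O)(=O)c3ccc(N)nc3)CC2)c1`: 44 mL.min-1.g-1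

Among the measured compounds shown here, compound 3 stands level with compound 2, the only other compound with a numeric value: a 1.1-fold higher number from compound 2 to compound 3 (0.04 log units; within the scatter), within the scatter. Replacing 2-cyclopropylethynyl with an aromatic group gave two steps beyond the scatter: an at least 2.8-fold higher number from compound 1 to compound 2 (0.45 log units; beyond the scatter) with 3-(methanesulfonamido)phenyl and an at least 3.1-fold higher number from compound 1 to compound 3 (0.49 log units; beyond the scatter) with 5-methoxypyridin-3-yl. Both are lower bounds on the true size of the step.

The next compound is compound 4 `Nc1ccc(S(=O)(=O)N2CCN(c3ncc(C(O)(C(F)(F)F)C(F)(F)F)cc3-c3cc4ccccc4[nH]3)CC2)cn1`, which carries 1H-indol-2-yl in place of 5-methoxypyridin-3-yl on an aromatic carbon. For the measured compounds named here, this swaps one aromatic group for another at the same place, as in a 1.1-fold higher number from compound 2 to compound 3 (0.04 log units; within the scatter), the closest precedent, which stayed within the scatter. Going by the values given here, that precedent rests on a single pair, and no measured compound carries the incoming group, so the range is kept wide. The estimated change is a 1.0-fold higher number from compound 3 to compound 4 (0.02 log units; within the scatter), which is expected to stay within the scatter, with no firm direction. For compound 4 the expected value in this assay is 46 mL.min-1.g-1, with an estimated range of 23 mL.min-1.g-1 to 92 mL.min-1.g-1.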

Compound 4, intrinsic clearance in microsomes: < 14 mL.min-1.g-1
Compound 4 was reported as a limit; the forecaster's own chance of this, stated with the estimate: 8%; at least 3.2-fold (0.51 log units) between middle value and limit.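

At this aromatic carbon, ortho to a large group, aromatic groups are not interchangeable in this assay: 1H-indol-2-yl gives an at least 3.1-fold lower number from compound 3 to compound 4 (0.49 log units; beyond the scatter) and an at least 2.8-fold lower number from compound 2 to compound 4 (0.45 log units; beyond the scatter), although the two earlier aromatic groups stood level with each other. The earlier link between an aromatic group at this place and a higher number therefore holds for compound 2 and compound 3, and compound 4 goes against it. The result for compound 4 is a limit of the assay and not a number, so both steps are lower bounds, and the step involving compound 1, also a limit, cannot be read: the limit of < 14 mL.min-1.g-1 in this assay, at which 2 of the 4 values shown sit.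

Open, from the compounds shown here alone, is whether the lower number follows the second ring or the hydrogen-bond donor, as 1H-indol-2-yl brings both at once. A pyrrol-2-yl or 1-methylindol-2-yl group would separate the two.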